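The source may hold more compounds than are shown below. What is called first, only, known or untested is meant among the compounds shown, and "the series" means these compounds.

In a functional assay on HUVEC cells (Homo sapiens) for inhibition, with stated times of 2 h and 72 h (on this read-out lower numbers stand for stronger inhibition and higher numbers for weaker inhibition), compound 1 (`COc1cc2nccc(Oc3ccc4c(NC(=O)C5CC5)nn(C)c4c3)c2cc1OC`) gives > 1000 nM, which is a limit of the assay. Compound 2 (`COc1ccc(NC(=O)Nc2nn(C)c3cc(Oc4ccnc5cc(OC)c(OC)cc45)ccc23)cc1`) gives > 1000 nM, also only a limit, and the limit of > 1000 nM in this assay, at which 2 of the 2 values shown sit, sums up the position. Compound 3 (`COc1cc2nccc(Oc3ccc4c(NCc5ccccc5)nn(C)c4c3)c2cc1OC`) follows from compound 2 by one change: benzyl in place of (4-methoxyphenyl)carbamoyl on a nitrogen on an aromatic ring. Among the compounds with values here, the one measured step, a step that the two limits leave unreadable from compound 1 to compound 2, joins two limits and sets no size, so no step of known size or direction is expected for compound 3 in this assay. The expected step is a step that the limit leaves unreadable from compound 2 to compound 3. Compound 3 is estimated at 1500 nM, with an expected range of 300 nM to 5000 nM.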

Compound 3, half-maximal inhibitory concentration: > 1000 nM
Compound 3 ended at the assay's limit (the forecaster's own chance of this, stated with the estimate: 65%); the middle value does not contradict the limit.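

No new step can be read among compound 1, compound 2 and compound 3 in this assay, as each value is only a limit: the limit of > 1000 nM in this assay, at which 3 of the 3 values shown sit.

The compounds shown leave open how large any of these changes on the shared core is, and in which direction it goes.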